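This account rests on a few compounds, and the source may have more. Where it says the series, first, only, none or still open, it means among the compounds named here.

Compound 1 `CO[C@@H]1[C@H](N(C)c2ncc(-c3c[nH]c4ccc(Cl)cc34)s2)C[C@H]2O[C@]1(C)n1c3ccccc3c3c4c(c5c6ccccc6n2c5c31)C(=O)NC4` gives 420 nM in a functional assay on MV4-11 cells (Homo sapiens) for antiproliferative activity, read by CellTiter-Glo, with a stated time of 72 h; a lower number here means a stronger inhibitor, a higher number a weaker inhibitor.
Compound 2 `CO[C@@H]1[C@H](N(C)c2ncc(-c3c[nH]c4ccccc34)s2)C[C@H]2O[C@]1(C)n1c3ccccc3c3c4c(c5c6cc(Cl)ccc6n2c5c31)C(=O)NC4` gives 560 nM in this assay.
Compound 3 `CO[C@@H]1[C@H](N(C)c2ncc(-c3c[nH]c4ccc(F)cc34)s2)C[C@H]2O[C@]1(C)n1c3ccccc3c3c4c(c5c6cc(Cl)ccc6n2c5c31)C(=O)NC4` gives 320 nM in this assay.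

Compound 3 has the lowest number of the three, but its gaps to compound 1 and to compound 2 both lie within the scatter, so no order among them is claimed. Compound 4 `CO[C@@H]1[C@H](N(C)c2ncc(-c3c[nH]c4ccc(Cl)cc34)s2)C[C@H]2O[C@]1(C)n1c3ccccc3c3c4c(c5c6cc(Cl)ccc6n2c5c31)C(=O)NC4` differs from compound 3 by chloro in place of fluoro on an aromatic carbon. Going by the values given here, the only measured step at this position is a 1.8-fold lower number from compound 2 to compound 3 (0.24 log units; within the scatter), within the scatter; compound 1, which carries a chloro at the same indole position, and compound 3 likewise sit within the scatter of each other. A halogen swap here is therefore expected to give no step beyond the scatter in this assay: compound 4 is estimated at 300 nM (range 130 nM to 700 nM), a step of a 1.1-fold lower number from compound 3 to compound 4 (0.03 log units; within the scatter).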

Compound 4, half-maximal inhibitory concentration: 590 nM
For compound 4 the middle estimate is 2.0-fold (0.29 log units) below the measured one, and the stated range covers the measured number.
By their numbers in this assay, from the lowest: compounds 3, 1, 2 and 4 (each within the scatter of the next).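

Chloro in place of fluoro at this indole carbon gives a 1.8-fold higher number from compound 3 to compound 4 (0.27 log units; within the scatter) in this assay, so exchanging these two halogens has no readable effect. Chloro in place of hydrogen at the same carbon gives a 1.1-fold higher number from compound 2 to compound 4 (0.02 log units; within the scatter), and chloro in place of hydrogen on the shared core gives a 1.4-fold higher number from compound 1 to compound 4 (0.15 log units; within the scatter), so neither addition separates from the scatter either. No evidence on the origin of these steps is available.
Still open, as far as these compounds go, is whether a methoxy group, a nitrile or an amine at this indole carbon would give a step beyond the scatter.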